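This account rests on a few compounds, and the source may have more. Where it says the series, first, only, none or still open, it means among the compounds named here.

Of the compounds shown here, three built on one shared core have so far been measured in a functional assay on MCF7 cells (Homo sapiens) for cytotoxicity; on this read-out lower numbers stand for stronger inhibition and higher numbers for weaker inhibition. Compound 1, `CC1C(=O)N(CCCCCOc2ccc(Cl)cc2)/C(=N\C#N)N1c1ccncc1`, gives 9260 nM. Compound 2, `CC1C(=O)N(CCCCCCOc2ccc(Cl)cc2)/C(=N\C#N)N1c1ccncc1`, gives 270 nM. Compound 3, `CCC1C(=O)N(CCCCCCOc2ccc(Cl)cc2)/C(=N\C#N)N1c1ccncc1`, gives 6910 nM.

The move from compound 1 to compound 2 is a single change, ((4-chlorophenoxy)methyl in place of 4-chlorophenoxy on a saturated chain carbon, five bonds along the chain from an amide-type nitrogen in a ring), and it brought a 34-fold lower number from compound 1 to compound 2 (1.54 log units; beyond the scatter). The move from compound 2 to compound 3 is also a single change, methyl in place of hydrogen on a saturated chain carbon bound to a saturated ring carbon, and it brought a 26-fold higher number from compound 2 to compound 3 (1.41 log units; beyond the scatter). The difference between the core of compound 1 and the core of compound 3 is not broken down here; their two values sit close together.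

Compound 4, `CCC1C(=O)N(CCCCCCCOc2ccc(Cl)cc2)/C(=N\C#N)N1c1ccncc1`, has not yet been measured. It differs from compound 3 by (4-chlorophenoxy)methyl in place of 4-chlorophenoxy on a saturated chain carbon, six bonds along the chain from an amide-type nitrogen in a ring. This is the same kind of change as that from compound 1 to compound 2, but not the same: there the place was five bonds along the chain from the amide-type nitrogen, here it is six bonds along. Because compound 2 showed a 34-fold lower number from compound 1 to compound 2 (1.54 log units; beyond the scatter) after lengthening the chain, compound 4 is expected to give a somewhat lower number than compound 3, though the chain here is already longer and the earlier gain need not repeat. The expected step is a 2.8-fold lower number from compound 3 to compound 4 (0.44 log units; beyond the scatter). Compound 4 is estimated at 2500 nM, within a wide range from 400 nM to 15000 nM.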

Compound 4, half-maximal inhibitory concentration: 4540 nM
Estimate against measurement, compound 4: 1.8-fold (0.26 log units) below, and the stated range covers the measured number.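

In this assay, the change from 4-chlorophenoxy to (4-chlorophenoxy)methyl, which adds one carbon to the chain, had a large effect on the first core, but on the other core it gives a 1.5-fold lower number from compound 3 to compound 4 (0.18 log units; within the scatter), so there the added carbon makes no readable difference. The gain seen on the first core therefore did not carry over to the second, and the gap between the two steps is larger than repeated measurements would normally produce: the same change on two cores in this assay, a 34-fold lower number (1.54 log units; beyond the scatter) from compound 1 to compound 2 and a 1.5-fold lower number (0.18 log units; within the scatter) from compound 3 to compound 4, 23-fold (1.35 log units) apart, beyond the scatter of two such steps

This does not show that the core alone decides the outcome, since the two changes also sit at different places, five and six bonds along the chain from the amide-type nitrogen, and a single pair of steps cannot separate these two differences or give a reason for either.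

Still open, going by these compounds, is how the chain of compound 4 would read on the core of compound 1, which would set the two cores side by side at one chain length, and how a longer chain would read on either core. Also open, on these data alone, is whether an amine or a carboxylic acid in place of the 4-chlorophenoxy group would keep any of this activity.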